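Removing a methoxy group from a curcuminoid terpene ether

The source may hold more compounds than are shown below. What is called first, only, known or untested is meant among the compounds shown, and "the series" means these compounds.

Measured compounds:
compound 1 `COc1cc(/C=C/C(=O)/C=C(O)/C=C/c2ccc(O[C@H]3C=C(C)[C@@H](O)C[C@@H]3[C@@H](C)CCC=C(C)C)c(OC)c2)ccc1O` gives 27300 nM;
compound 2 `COc1cc(/C=C/C(=O)/C=C(O)/C=C/c2ccc(O[C@H]3C[C@H]([C@@H](C)CCC=C(C)C)C=C[C@@]3(C)O)c(OC)c2)ccc1O` gives 24600 nM;
compound 3 `COc1cc(/C=C/C(=O)/C=C(O)/C=C/c2ccc(O[C@H]3C=C(C)[C@@H](O)C[C@@H]3[C@@H](C)CC(=O)C=C(C)C)c(OC)c2)ccc1O` gives 10600 nM.

All three were tested in a functional assay on MDA-MB-231 cells (Homo sapiens) for cytotoxicity, read by crystal violet staining, with a stated time of 72 h; on this read-out lower numbers stand for stronger inhibition and higher numbers for weaker inhibition. Compound 3 shows the lowest number of the three, and its gap to compound 2 and to compound 1 lies beyond the scatter. Among the compounds with values here, the one step that can be followed, a 2.6-fold lower number from compound 1 to compound 3 (0.41 log units; beyond the scatter), is modest.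

Compound 4 `COc1cc(/C=C/C(O)=C/C(=O)/C=C/c2ccc(O)cc2)ccc1O[C@H]1C=C(C)[C@@H](O)C[C@@H]1[C@@H](C)CC(=O)C=C(C)C` has not been measured. It differs from compound 3 in one place: hydrogen in place of methoxy on an aromatic carbon. The change sits on the aromatic ring that is not joined to the terpene ether, ortho to the hydroxy group and meta to a large group.

Within the data shown here, no measured step touches this part of the molecule; the only step seen, from compound 1 to compound 3, concerns the chain on the ring of the terpene ether. There is therefore no basis for expecting a shift in either direction beyond the scatter, and compound 4 is estimated to stay close to compound 3, with a 1.0-fold higher number from compound 3 to compound 4 (0.02 log units; within the scatter) as the expected step. The estimate for compound 4 is 11000 nM, in a range from 4500 nM to 27000 nM.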

Compound 4, half-maximal inhibitory concentration: 10300 nM
Estimate against measurement, compound 4: 1.1-fold (0.03 log units) above, within the range that was stated.
By their numbers in this assay, from the lowest: compounds 4 and 3 (each within the scatter of the next); then compounds 2 and 1 (each within the scatter of the next).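

Within the data shown here, this pair gives the first reading at this position: going from 4-hydroxy-3-methoxyphenyl to 4-hydroxyphenyl, with hydrogen in place of methoxy, is a 1.0-fold lower number from compound 3 to compound 4 (0.01 log units; within the scatter) in this assay. So, in the setting of compound 3, the methoxy group on this ring can be removed without any difference that can be told from the usual scatter, whereas the one earlier step concerned the chain of the terpene ether. No supporting measurement bears on why the two compounds read alike.

Only methoxy and hydrogen are seen at this position, so an ethoxy group, a chlorine atom or an amine there remains an open question. Also open, on these data alone, is whether the same swap would read alike on the ring that carries the terpene ether, where a methoxy group remains in compound 4.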